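Methoxy for Fluoro on the Aryl Ring of Compound 2

The source may report more compounds than this note shows. Statements on the series, on what has been measured and on what is new or still open speak of the compounds shown alone.

The account concerns two measured compounds and one that awaits its number. Compound 1, `COc1cc(C(=O)/C=C/c2c(-c3cccs3)nc3ccccn23)cc(OC)c1OC`, and compound 2, `COc1cc(C(=O)/C=C/c2c(-c3ccc(F)cc3)nc3ncccn23)cc(OC)c1OC`, share a core and differ in several places at once. In a functional assay on A549 cells (Homo sapiens) for inhibition, read by sulforhodamine B assay, with a stated time of 48 h (on this read-out higher numbers stand for weaker inhibition of growth and lower numbers for stronger inhibition of growth), compound 1 gives 2040 nM. In the same this assay compound 2 gives 3340 nM, and this number sits within the usual scatter of the number for compound 1, so no order between the two can be read from them.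

Compound 3, `COc1ccc(-c2nc3ncccn3c2/C=C/C(=O)c2cc(OC)c(OC)c(OC)c2)cc1`, is the next compound, and it differs from compound 2 in one place: methoxy in place of fluoro on an aromatic carbon. Going by the values given here, no step of this kind has been measured among the compounds here, so the expectation rests on the change alone. The step expected from compound 2 to compound 3 in this assay is a 1.2-fold lower number from compound 2 to compound 3 (0.09 log units; within the scatter), a shift no larger than the scatter, in either direction. On that basis compound 3 is estimated at 2700 nM in this assay, with a range from 900 nM to 8000 nM.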

Compound 3, concentration for 50% growth inhibition: 2710 nM
Compound 3: middle estimate off by 1.0-fold (0.00 log units), on the low side; the measured number falls inside the stated range.
By their numbers in this assay, from the lowest: compounds 1, 3 and 2 (each within the scatter of the next).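

In this assay, going by these compounds alone, the change from 4-fluorophenyl to 4-methoxyphenyl gives a 1.2-fold lower number from compound 2 to compound 3 (0.09 log units; within the scatter) and is the only step here that isolates one place, whereas compound 1 differs from compound 2 in several places at once. At this position, on an aromatic carbon para to a large group, methoxy in place of fluoro therefore leaves the number within the scatter, although it brings a hydrogen-bond acceptor that fluoro does not count. There is no evidence here that explains this result.

From the compounds shown here alone, whether an amine or a carboxylic acid at this position would also leave the number within the scatter remains open. So does the outcome with a longer chain, such as butoxy, in place of methoxy.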